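A few compounds are considered here, and "the series" means these few. Any claim that something is new, unique, unknown or untested is made for them only; others in the source may bear on it.

Measured so far:
- compound 1 `Cc1ccc(S(=O)(=O)n2c(C3(O)C=CC(=O)C=C3)cc3ccccc32)cc1` — 48 nM in a functional assay on HCT-116 cells (Homo sapiens); a higher number here means that more compound is tolerated, a lower number that less compound is tolerated
- compound 2 `Cc1ccc(S(=O)(=O)n2c(C3(O)C=CC(=O)c4ccccc43)cc3ccccc32)cc1` — in this assay compound 2 gives 450 nM

Compound 1 stands at the lower of the two numbers recorded, with compound 2 the nearer and only neighbour, beyond the scatter. Compound 3 `O=C1C=CC(O)(c2cc3ccccc3n2S(=O)(=O)c2ccc3ccccc3c2)C=C1` is not yet measured; it differs from compound 1 in one place: naphthalen-2-yl in place of 4-methylphenyl on a sulfonyl sulfur. Among the compounds with values here, no measured pair shows this kind of change, so nothing comparable is available. The change keeps the core of compound 1 and the rest of the molecule untouched, and an aromatic group on the sulfonyl sulfur is exchanged for another. The step from compound 1 to compound 3 is expected to be small, within or close to the scatter, with no clear direction, as a 1.3-fold higher number from compound 1 to compound 3 (0.10 log units; within the scatter). Compound 3 is estimated at 60 nM in this assay, with a range from 20 nM to 200 nM.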

Compound 3, concentration lethal to 50% of the cells: 370 nM
Compound 3: middle estimate off by 6.2-fold (0.79 log units), on the low side; the measured number lies above the stated range.
By their numbers in this assay, from the lowest: compound 1; then compounds 3 and 2 (each within the scatter of the next).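

In this assay, the group on a sulfonyl sulfur whose other neighbour is the aromatic nitrogen proves to be a responsive position: naphthalen-2-yl in place of 4-methylphenyl gives a 7.7-fold higher number from compound 1 to compound 3 (0.89 log units; beyond the scatter), with the shared core unchanged. Within the data shown here, this is the only step read at this position, so it shows that exchanging one carbon-only aromatic group for another can move the number beyond the scatter, towards more compound tolerated, but it establishes no trend. No available measurement bears on the reason for this step.

As far as these compounds go, it remains open whether a methyl group on the sulfonyl sulfur, or a phenyl group carrying an amine or a carboxylic acid, would stay near compound 1 or move towards compound 3. Also open, from the compounds shown here alone, is whether the same exchange would give a similar step on the core of compound 2.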